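Step from compound 2 to compound 3

The source may hold more compounds than are shown below. What is called first, only, known or untested is meant among the compounds shown, and "the series" means these compounds.

Values in a functional assay on MIA PaCa-2 cells (Homo sapiens) for cytotoxicity, read by MTT assay, with a stated time of 4 h; on this read-out higher numbers stand for weaker inhibition and lower numbers for stronger inhibition:
- compound 1 `COC1=CC(=O)c2c(COc3ccccc3)c(C)n(C)c2C1=O`: 4560 nM
- compound 2 `COC1=CC(=O)c2c(COc3ccc(F)cc3)c(C)n(C)c2C1=O`: 905 nM

Of the two measured compounds, compound 2 holds the lower number, at 905 nM in this assay. The next compound, compound 3 `COC1=CC(=O)c2c(COc3ccncc3)c(C)n(C)c2C1=O`, keeps the shared core and differs in one group: pyridin-4-yl in place of 4-fluorophenyl on an oxygen on a saturated carbon. In words, pyridin-4-yl stands in place of 4-fluorophenyl on an oxygen on a saturated carbon.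

Among the measured compounds shown here, only one measured step bears on this change: a 5.0-fold lower number from compound 1 to compound 2 (0.70 log units; beyond the scatter). It is modest but beyond the scatter, and it came with fluoro in place of hydrogen on an aromatic carbon. Compound 3 has no fluoro, and in that respect it resembles compound 1, at 4560 nM in this series. For the measured compounds named here, no measured compound has a hetero atom in this aromatic ring, so the effect of that feature remains unknown. A step of similar or smaller size towards a higher number is therefore expected, with wide uncertainty. The expected step is a 3.1-fold higher number from compound 2 to compound 3 (0.49 log units; beyond the scatter) in this assay. For compound 3 the estimate is 2800 nM, with an expected range of 800 nM to 10000 nM as the measurement is awaited.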

Compound 3, half-maximal inhibitory concentration: 2560 nM
The estimate for compound 3 lay 1.1-fold (0.04 log units) above the measured number; the measured number falls inside the stated range.
By their numbers in this assay, from the lowest: compound 2; then compounds 3 and 1 (each within the scatter of the next).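

Compared with the phenyl group, pyridin-4-yl on this oxygen gives a 1.8-fold lower number from compound 1 to compound 3 (0.25 log units; within the scatter) in this assay, so this is the first sign that a hetero atom in the ring can be accommodated with no difference that can be told from the scatter. Compared with 4-fluorophenyl, the same group gives a 2.8-fold higher number from compound 2 to compound 3 (0.45 log units; beyond the scatter) in this assay, so the ring nitrogen does not match the lower number seen with the fluoro group. Among these three compounds, compound 2 alone stands apart from the other two by steps beyond the scatter, which makes the 4-fluorophenyl group, not simply any change to the phenyl ring, the feature linked to the lower number so far, though no available evidence accounts for this difference.

Still open, as far as these compounds go, is whether the fluoro step carries over to the pyridine ring, as a fluoro-substituted pyridinyl group would show, and whether chloro, methoxy or an amine in place of the fluoro on the phenyl ring would give a similar number. Also open, from the compounds shown here alone, are pyridin-2-yl and pyridin-3-yl, which would show whether the result depends on where the ring nitrogen lies.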